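A few compounds are considered here, and "the series" means these few. Any claim that something is new, unique, unknown or untested is made for them only; others in the source may bear on it.

Compound 1 `Cc1nn(-c2ccccc2)c2nc(-c3ccc(C(F)(F)F)cc3)c(C#N)c(-c3ccccc3O)c12` gives 3500 nM
Compound 2 `Cc1nn(-c2ccccc2)c2nc(-c3ccc(F)cc3)c(C#N)c(-c3ccccc3O)c12` gives 6000 nM
Compound 3 `Cc1nn(-c2ccccc2)c2nc(-c3ccc(Cl)cc3)c(C#N)c(-c3ccccc3O)c12` gives 3800 nM

All three numbers come from a physicochemical assay for solubility, read by spectrophotometry, in phosphate buffer, with a stated time of 18 h, at pH 7.4 (a lower number here means a less soluble compound, a higher number a more soluble compound), and lie close together. Compound 3 stands within the scatter of both others, with a 1.1-fold higher number from compound 1 to compound 3 (0.04 log units; within the scatter) and a 1.6-fold lower number from compound 2 to compound 3 (0.20 log units; within the scatter) as its two steps. Compound 4 `Cc1nn(-c2ccccc2)c2nc(-c3ccc4c(c3)OCCO4)c(C#N)c(-c3ccccc3O)c12` carries 2,3-dihydro-1,4-benzodioxin-6-yl in place of 4-chlorophenyl on an aromatic carbon next to the ring nitrogen 2,3-dihydro-1,4-benzodioxin-6-yl in place of 4-chlorophenyl on an aromatic carbon and is still to be measured. The measured steps that bear on this change exchange only the group on that same aromatic ring. Besides the two above, there is a 1.7-fold higher number from compound 1 to compound 2 (0.23 log units; within the scatter) and none of the three goes beyond the scatter. Among the measured compounds shown here, no measured compound carries 2,3-dihydro-1,4-benzodioxin-6-yl, so the evidence is indirect and the range must stay wide. No step beyond the scatter is therefore expected in this assay and no direction can be favoured. The expected step is a 1.1-fold lower number from compound 3 to compound 4 (0.04 log units; within the scatter) as a best estimate. For compound 4 the estimated value is 3500 nM with an expected range from 1500 nM to 7500 nM in this measurement.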

Compound 4, solubility: 11000 nM
For compound 4 the middle estimate is 3.1-fold (0.50 log units) below the measured one, and the stated range ends below it.
By their numbers in this assay, from the lowest: compounds 1, 3, 2 and 4 (each within the scatter of the next, the first and the last beyond it).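

Compound 4 is the first of the compounds shown to step beyond the scatter at this position in this assay, so a change on the aromatic carbon next to the ring nitrogen can move this read-out, as the exchanges among the three substituted phenyl groups did not. Putting 2,3-dihydro-1,4-benzodioxin-6-yl in place of 4-chlorophenyl gives a 2.9-fold higher number from compound 3 to compound 4 (0.46 log units; beyond the scatter) and in place of 4-(trifluoromethyl)phenyl gives a 3.1-fold higher number from compound 1 to compound 4 (0.50 log units; beyond the scatter), but compound 2 goes against a clean separation (a 1.8-fold higher number from compound 2 to compound 4 (0.26 log units; within the scatter)). Nothing measured alongside these numbers accounts for the difference.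

As far as these compounds go, it remains open whether the non-aromatic ring itself matters or whether the two oxygens alone would do, as a phenyl group carrying two methoxy groups would show. Also open, from the compounds shown here alone, is how an amine or a carboxylic acid on that phenyl ring would read.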